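Swapping Trifluoromethyl for Nitro: Expected Cytotoxicity of Compound 4

A few compounds are considered here, and "the series" means these few. Any claim that something is new, unique, unknown or untested is made for them only; others in the source may bear on it.

Compound 1 `O=c1[nH]c(Nc2cc(F)cc(F)c2)nc2cc(Cl)ccc12`: >= 18000 nM
Compound 2 `O=c1[nH]c(Nc2cccc(C(F)(F)F)c2)nc2cc(Cl)ccc12`: > 25000 nM
Compound 3 `O=c1[nH]c(Nc2cc(F)cc(F)c2)nc2cc(C(F)(F)F)ccc12`: >= 7600 nM

In an ADME assay on Vero cells (Chlorocebus sabaeus) for cytotoxicity, read by WST assay (on this read-out higher numbers stand for lower toxicity in this test and lower numbers for higher toxicity in this test), compound 1 reaches only a limit, >= 18000 nM, not a number. Compound 2 likewise reaches only a limit, > 25000 nM. Compound 3 also reaches only a limit, >= 7600 nM, so it sits at the limit of >= 7600 nM in this assay, at which 1 of the 3 values shown sits, and cannot be ranked against the other two. The step that the two limits leave unreadable from compound 1 to compound 3 therefore has no readable size. Compound 4 `O=c1[nH]c(Nc2cc(F)cc(F)c2)nc2cc([N+](=O)[O-])ccc12` differs from compound 3 by nitro in place of trifluoromethyl on an aromatic carbon. Within the data shown here, no measured step covers a nitro group, and the one step at this position is unreadable, so no direction can be drawn from the data. The step that the limit leaves unreadable from compound 3 to compound 4 is expected to stay within scatter. Compound 4 is therefore estimated at 15000 nM, between 4000 nM and 50000 nM.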

Compound 4, half-maximal cytotoxic concentration: > 25000 nM
Compound 4 was reported as a limit; the forecaster's own chance of this, stated with the estimate: 60%; middle value at least 1.6-fold (0.22 log units) from the limit.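

Compound 4 gives only a limit in this assay, as do compound 1 and compound 3, so neither step to compound 4 can be read. The compounds shown leave open whether chloro, trifluoromethyl and nitro at this place differ in toxicity at all.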